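The source may report more compounds than this note shows. Statements on the series, on what has been measured and on what is new or still open speak of the compounds shown alone.

Measured compounds:
compound 1 `OCc1cn(Cc2cccc(Cl)c2)c2ccccc12` – 160 nM
compound 2 `Cc1cccc(Cn2cc(CO)c3ccccc32)c1` – 1000 nM
compound 3 `OCc1cn(Cc2ccc(Cl)cc2)c2ccc(F)cc12` – 80 nM

All three values come from a functional assay on T29Kt1 cells (Homo sapiens) for cytotoxicity, read by sulforhodamine B assay, with a stated time of 3 days; a lower number here means a stronger inhibitor, a higher number a weaker inhibitor. Going by the values given here, the only measured instance of the change of interest is methyl in place of chloro on an aromatic carbon, which gave a 6.3-fold higher number from compound 1 to compound 2 (0.80 log units; beyond the scatter). Compound 4 `Cc1ccc(Cn2cc(CO)c3cc(F)ccc32)cc1` is not yet measured; it differs from compound 3 by methyl in place of chloro on an aromatic carbon. The surroundings of the place are not identical: from compound 1 to compound 2 the place is meta to a large group, from compound 3 to compound 4 it is para to a large group, so this is the same kind of change rather than the same one. The difference between the core of compound 1 and the core of compound 3 is not broken down here; the values of compound 3 and compound 1 lie within the scatter of each other, while compound 2 stands beyond the scatter above both.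

The measured step to set beside the expected one is a 6.3-fold higher number from compound 1 to compound 2 (0.80 log units; beyond the scatter). The step from compound 3 to compound 4 is expected to be of similar direction but allowed somewhat smaller, as the place differs; the expected step is a 5.0-fold higher number from compound 3 to compound 4 (0.70 log units; beyond the scatter). Compound 4 is therefore estimated at 400 nM in this assay, with a range from 150 nM to 1200 nM.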

Compound 4, half-maximal inhibitory concentration: 30 nM
Beside the measured number, compound 4's estimate is 13-fold (1.12 log units) above it, outside the stated range (below it).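

In this assay, methyl in place of chloro on an aromatic carbon, para to a large group, gave a 2.7-fold lower number from compound 3 to compound 4 (0.43 log units; beyond the scatter). The change therefore did not carry its direction from one core to the other, and a step measured on one of these cores is a poor guide to the step on the other: the same change on two cores in this assay, a 6.3-fold higher number (0.80 log units; beyond the scatter) from compound 1 to compound 2 and a 2.7-fold lower number (0.43 log units; beyond the scatter) from compound 3 to compound 4, 17-fold (1.22 log units) apart, beyond the scatter of two such steps. This does not show why the two steps differ, since the two pairs differ both in core and in the place of the change, and two pairs give no general rule for the series.

Still open, on these data alone, is whether the reversal follows the core or the place, which would need methyl and chloro compared at one place on each core. Also open, as far as these compounds go, is how methoxy or trifluoromethyl would behave at that place, and what a carboxylic acid or a longer chain would do in place of the hydroxymethyl group.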